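Extending the aryl group in the core of compound 3

The source may hold more compounds than are shown below. What is called first, only, known or untested is meant among the compounds shown, and "the series" means these compounds.

Measured so far:
- Compound 1 `Brc1cn2ccnc2c(-c2ccc3ncn(C4CCCCC4)c3c2)n1`: 13.1%
- Compound 2 `CCc1ccc(-c2cn3ccnc3c(-c3ccc4ncn(Cc5ccccc5)c4c3)n2)cc1`: 74.7%
- Compound 3 `Cc1cccc(-c2cn3ccnc3c(-c3ccc4ncn(Cc5ccccc5)c4c3)n2)c1`: 35.2%

In a functional assay on HCT-15 cells (Homo sapiens) for inhibition, read by sulforhodamine B assay, with a stated time of 48 h, tested at 10 uM (a higher number here means more inhibition at the concentration tested (going by the name of the read-out), a lower number less inhibition), compound 3 gives 35.2%, the second highest of the three numbers. Within the data shown here, compound 1 sits well under it, while compound 2 stands clearly above it, and the only single-place step among the measured compounds is a number 39.5 percentage points lower from compound 2 to compound 3 (beyond the scatter).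

Compound 4 `c1ccc(Cn2cnc3ccc(-c4nc(-c5cccc6ccccc56)cn5ccnc45)cc32)cc1` is not yet measured. It differs from compound 3 in one place: naphthalen-1-yl in place of 3-methylphenyl on an aromatic carbon. Among the measured compounds shown here, no measured step swaps one aryl group for a group with two six-membered aromatic rings of carbon only, so there is no direct guide. For the measured compounds named here, the one related step, a number 39.5 percentage points lower from compound 2 to compound 3 (beyond the scatter), shows that even a small exchange of the group at this position can move this assay a great deal, so a sizeable move in either direction is possible. Going by the values given here, with no closer analogue, the estimate for compound 4 is placed near the middle of the measured range and left wide: 45% (range 15% to 80%), meaning an expected step of a number 9.8 percentage points higher from compound 3 to compound 4 (within the scatter).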

Compound 4, a percentage reported as inhibition, at one concentration (the size of the read-out at that concentration, not a potency): 8.2%
Compound 4: the middle estimate sits 36.8 percentage points above what was measured; the measured number lies below the stated range.
By their numbers in this assay, from the lowest: compounds 4 and 1 (each within the scatter of the next); then compound 3; then compound 2.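

In this assay, a second fused aromatic ring at this position brings no gain in inhibition: naphthalen-1-yl in place of 3-methylphenyl gives a number 27 percentage points lower from compound 3 to compound 4 (beyond the scatter), and naphthalen-1-yl in place of 4-ethylphenyl gives a number 66.5 percentage points lower from compound 2 to compound 4 (beyond the scatter). Naphthalen-1-yl carries more heavy atoms and one more ring than 3-methylphenyl, yet the number falls, so simply adding aromatic carbon here does not raise inhibition. Nothing measured gives a reason for these drops.

The compounds shown leave open whether the high number of compound 2 depends on the length of its alkyl group or on where that group sits on the phenyl ring, as 4-ethylphenyl and 3-methylphenyl differ in both. Also open, on these data alone, is how a phenyl ring carrying an amine, a carboxylic acid or a longer chain such as butyl would behave at this position.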